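This account rests on a few compounds, and the source may have more. Where it says the series, first, only, none or still open, it means among the compounds named here.

Measured in an ADME assay on MT4 cells (Homo sapiens) for cytotoxicity, read by MTT assay; a higher number here means that more compound is tolerated, a lower number that less compound is tolerated:
- compound 1 `Cc1cc(C)cc(S(=O)(=O)c2c(C(=O)NC(C)C(=O)NC(C)c3ccccc3)[nH]c3ccc(Cl)cc23)c1`: 21700 nM
- compound 2 `Cc1cc(C)cc(S(=O)(=O)c2c(C(=O)NC(C)c3ccco3)[nH]c3ccc(Cl)cc23)c1`: > 54700 nM (a limit)

Compound 2 stands at the limit of > 54700 nM in this assay, at which 1 of the 2 values shown sits, so it has a limit and no number. The next analogue is compound 3 `Cc1cc(C)cc(S(=O)(=O)c2c(C(=O)NC(C)C(=O)NC(C)c3ccccc3F)[nH]c3ccc(Cl)cc23)c1`, with (1-(2-fluorophenyl)ethyl)carbamoyl in place of furan-2-yl on a saturated chain carbon bound to an amide-type nitrogen and a saturated chain carbon. Within the data shown here, only one measured step bears on this change: an at least 2.5-fold higher number from compound 1 to compound 2 (0.40 log units; beyond the scatter). That step put furan-2-yl in place of (1-phenylethyl)carbamoyl, and the present change runs the opposite way with a closely related group. A step of similar size toward a lower number is therefore expected. The expected step in this assay is an at least 2.7-fold lower number from compound 2 to compound 3 (0.43 log units; beyond the scatter). For compound 3 the estimate is 20000 nM, with an expected range of 9000 nM to 45000 nM.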

Compound 3, half-maximal cytotoxic concentration: 15200 nM
Estimate against measurement, compound 3: 1.3-fold (0.12 log units) above; low and high end bracket the measured number.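

In this assay, fluoro in place of hydrogen on an aromatic carbon gives a 1.4-fold lower number from compound 1 to compound 3 (0.15 log units; within the scatter), so this substitution leaves no readable change. The swap of furan-2-yl for (1-(2-fluorophenyl)ethyl)carbamoyl gives an at least 3.5-fold lower number from compound 2 to compound 3 (0.55 log units; beyond the scatter), which repeats in a second pair the separation first seen with the unfluorinated group. Compound 2 has only a limit, not a number: the limit of > 54700 nM in this assay, at which 1 of the 3 values shown sits.

Going by these compounds, the full size of both steps from compound 2 stays open. Also open, on these data alone, is whether an amine or a carboxylic acid at this place would track furan-2-yl or the carbamoyl groups.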